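From Dimethylamino to Methylamino on Compound 1

The source may report more compounds than this note shows. Statements on the series, on what has been measured and on what is new or still open speak of the compounds shown alone.

Measured so far in a functional assay on the whole organism with Rattus norvegicus as the target; a lower number here means that less compound is needed, a higher number that more compound is needed for the effect
- compound 1 `CCOC(=O)C(=O)Nc1cccc(N(C)C)c1C#N` gives 4.2 mg/kg
- compound 2 `CCOC(=O)C(=O)Nc1ccc(N(C)C)cc1C#N` gives 2.4 mg/kg
- compound 3 `CCOC(=O)C(=O)Nc1ccc(N)cc1C#N` gives 8.8 mg/kg

Compound 1 lies within the usual scatter of compound 2, while compound 3 stands clearly higher than both. The next compound to test is compound 4 `CCOC(=O)C(=O)Nc1cccc(NC)c1C#N`. It differs from compound 1 as follows: hydrogen in place of methyl on a nitrogen on an aromatic ring. In words, a hydrogen takes the place of a methyl on a nitrogen on an aromatic ring, turning dimethylamino into methylamino.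

Within the data shown here, only one measured step bears on this change, namely a 3.7-fold higher number from compound 2 to compound 3 (0.56 log units; beyond the scatter). That step goes all the way from dimethylamino to amino, and it was measured on compound 2, not on compound 1. It is modest but beyond the scatter, and it points towards a higher number in this assay. Going only as far as methylamino should therefore move the number in the same direction, but by less. With a single step as a guide, the expected change may not clear the scatter. The expected step is a 1.5-fold higher number from compound 1 to compound 4 (0.19 log units; within the scatter). For compound 4 the estimated value is 6.5 mg/kg, with an expected range from 3 mg/kg to 14 mg/kg.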

Compound 4, dose for half-maximal effect: 0.1 mg/kg
Beside the measured number, compound 4's estimate is 65-fold (1.81 log units) above it; measured number below the stated range.
By their numbers in this assay, from the lowest: compound 4; then compounds 2 and 1 (each within the scatter of the next); then compound 3.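

In this assay, among these compounds, a single methyl on this nitrogen turns out to matter far more than the earlier compounds suggested: the step to methylamino gives a 42-fold lower number from compound 1 to compound 4 (1.62 log units; beyond the scatter) and so moves the number by a large amount through the loss of just one carbon. Among the compounds shown here, the only earlier step on such a nitrogen, a 3.7-fold higher number from compound 2 to compound 3 (0.56 log units; beyond the scatter), runs the opposite way, although it removes both methyls and belongs to a different pair of compounds. Taken together, these two steps show that taking methyls off this nitrogen has no single direction across the compounds shown, and that the outcome depends on how many methyls go, on where the nitrogen sits, or on both, and nothing available here explains the large change.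

The compounds shown leave open whether the low number is specific to methylamino, or whether ethylamino, with its longer chain on the same nitrogen, would keep it. They also leave open whether the ester end of the molecule matters to this result, for example whether a carboxylic acid in place of the ethyl ester would preserve the number reached with methylamino.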